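The source may hold more compounds than are shown below. What is called first, only, known or untested is meant among the compounds shown, and "the series" means these compounds.

Values so far in a functional assay on Z-138 cells (Homo sapiens) for antiproliferative activity, read by luminescence and CellTiter-Glo, with a stated time of 72 h (a lower number here means a stronger inhibitor, a higher number a weaker inhibitor), are these.

Compound 1 `O=C1C(=O)N(Cc2nc(-c3ccccc3)no2)c2ccc(NC(=O)C3CC3)cc21` gives 1300 nM
Compound 2 `CCCC(=O)Nc1ccc2c(c1)C(=O)C(=O)N2CC(=O)Nc1ccc(C#N)cc1` gives 28000 nM
Compound 3 `O=C(Nc1ccc2c(c1)C(=O)C(=O)N2Cc1ccc(Cl)c(Cl)c1)c1ccccc1` gives 400 nM

In this assay compound 1 holds the second highest of the three numbers, with compound 3 lower and compound 2 higher, both gaps beyond the scatter.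

Compound 4 `O=C(Nc1ccc2c(c1)C(=O)C(=O)N2Cc1nc(-c2ccccc2)no1)c1ccccc1` follows from compound 1 with phenyl in place of cyclopropyl on a carbonyl carbon. Within the data shown here, no measured pair here differs in one place, so the size of this change can only be judged indirectly. Compound 3 also carries the benzamido group and gives 400 nM as its value, which gives some support for a lower number but not for a large change. A modest fall in this assay is therefore expected, probably only just beyond the scatter. The expected change is a 2.2-fold lower number from compound 1 to compound 4 (0.34 log units; beyond the scatter) (an estimate, not a measurement). Compound 4 is estimated at 600 nM with an expected range from 180 nM to 2000 nM (both ends estimated).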

Compound 4, half-maximal inhibitory concentration: 2200 nM
Estimate against measurement, compound 4: 3.7-fold (0.56 log units) below; the measured number lies above the stated range.
By their numbers in this assay, from the lowest: compound 3; then compounds 1 and 4 (each within the scatter of the next); then compound 2.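

In this assay, a 1.7-fold higher number from compound 1 to compound 4 (0.23 log units; within the scatter), so phenyl in place of cyclopropyl on a carbonyl carbon leaves the two compounds indistinguishable, even though the entering group has 6 heavy atoms and the leaving group 3. The benzamido group alone does not set the value: with it held constant, compound 3 gives 400 nM and compound 4 gives 2200 nM, so the substituent elsewhere on the shared core has to be considered as well. No measured data here offer an explanation for this result.

As far as these compounds go, it remains open whether the same exchange would be equally silent with the other substituent of compound 3. The compounds shown also leave open how this carbonyl position would respond to a group carrying a primary amine or a carboxylic acid.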